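Trimming an aroyl to a propanoyl on the shared core

The source may hold more compounds than are shown below. What is called first, only, known or untested is meant among the compounds shown, and "the series" means these compounds.

Compound 3 `Cc1ccc(C(=O)N2N=C(c3cc4ccccc4oc3=O)CC2c2ccccc2)cc1` gives 52300 nM in a functional assay on HepG2 cells (Homo sapiens) for cytotoxicity, read by MTT assay, with a stated time of 48 h (a higher number here means a weaker inhibitor, a lower number a stronger inhibitor), the highest of three numbers, yet within the scatter of both compound 1 `CCC(=O)N1N=C(C)CC1c1cc(Br)cc(Br)c1O` at 41400 nM and compound 2 `O=C(c1ccccc1)N1N=C(c2cc3ccccc3oc2=O)CC1c1ccccc1` at 36600 nM. Compound 4 `CCC(=O)N1N=C(c2cc3ccccc3oc2=O)CC1c1ccccc1` carries ethyl in place of 4-methylphenyl on a carbonyl carbon. Within the data shown here, the only measured step on this core, a 1.4-fold higher number from compound 2 to compound 3 (0.16 log units; within the scatter), shows that changing the aroyl group hardly moved this assay, and compound 1, with the same propanoyl group but a different core, sits in the same range. Among the measured compounds shown here, no step speaks for a shift beyond the scatter, so compound 4 is expected to show a 1.2-fold lower number from compound 3 to compound 4 (0.10 log units; within the scatter). Compound 4 is therefore estimated at 42000 nM, within 15000 nM to 115000 nM.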

Compound 4, half-maximal inhibitory concentration: 9610 nM
The estimate for compound 4 lay 4.4-fold (0.64 log units) above the measured number, and the stated range ends above it.
By their numbers in this assay, from the lowest: compound 4; then compounds 2, 1 and 3 (each within the scatter of the next).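

On the shared core, the group on the carbonyl carbon does matter in this assay: ethyl in place of 4-methylphenyl gives a 5.4-fold lower number from compound 3 to compound 4 (0.74 log units; beyond the scatter), and ethyl in place of phenyl gives a 3.8-fold lower number from compound 2 to compound 4 (0.58 log units; beyond the scatter). The earlier methyl change on the aromatic ring stayed within the scatter, whereas removing the ring altogether moves the number beyond it. Nothing available accounts for this step. Going by these compounds, whether a longer chain such as butyl, or an amine on that carbonyl carbon, would keep the lower number remains open.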